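Ring nitrogen substituents in a carboxylic acid series

The source may hold more compounds than are shown below. What is called first, only, known or untested is meant among the compounds shown, and "the series" means these compounds.

Values in an assay on HEK-293T cells for antagonist activity at vitamin D3 receptor (Homo sapiens), read by a luciferase reporter, with a stated time of 24 h; on this read-out lower numbers stand for stronger inhibition and higher numbers for weaker inhibition:
compound 1 `CC(C)c1onc(-c2c(Cl)cccc2Cl)c1COc1ccc(-c2nc3ccc(C(=O)O)cc3n2C)cc1`: 7150 nM
compound 2 `CC(C)c1onc(-c2c(Cl)cccc2Cl)c1COc1ccc(-c2nc3ccc(C(=O)O)cc3n2C(C)C)cc1`: 3550 nM
compound 3 `CC(=O)N1CCC(n2c(-c3ccc(OCc4c(-c5c(Cl)cccc5Cl)noc4C(C)C)cc3)nc3ccc(C(=O)O)cc32)CC1`: > 10000 nM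

For compound 3 only a limit of the assay is known, > 10000 nM in this assay, so its position within the set is open; of the three it alone sits at the limit of > 10000 nM in this assay, at which 1 of the 3 values shown sits.

Compound 4 `CC(C)c1onc(-c2c(Cl)cccc2Cl)c1COc1ccc(-c2nc3ccc(C(=O)O)cc3n2C2CCCC2)cc1` introduces (cyclopentyl in place of 1-acetylpiperidin-4-yl on an aromatic nitrogen). Within the data shown here, two measured steps bear on this: a 2.0-fold lower number from compound 1 to compound 2 (0.30 log units; within the scatter), and an at least 2.8-fold higher number from compound 2 to compound 3 (0.44 log units; beyond the scatter); in addition an at least 1.3-fold higher number from compound 1 to compound 3 (0.14 log units; that floor lies within the scatter). Cyclopentyl, a ring of carbon only, stands nearer to isopropyl than to 1-acetylpiperidin-4-yl, so the step in this assay is expected to run back toward the value of compound 2, giving a lower number beyond the scatter.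

Compound 4 is therefore estimated at 3500 nM, with a range of 1500 nM to 9000 nM. The expected step is an at least 2.8-fold lower number from compound 3 to compound 4 (0.45 log units; beyond the scatter).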

Compound 4, half-maximal inhibitory concentration: 929 nM
The estimate for compound 4 lay 3.8-fold (0.58 log units) above the measured number; measured number outside the range, below it.
By their numbers in this assay, from the lowest: compound 4; then compounds 2 and 1 (each within the scatter of the next). At a limit, above all of these: compound 3.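

On the aromatic nitrogen in this assay, cyclopentyl gives a 3.8-fold lower number from compound 2 to compound 4 (0.58 log units; beyond the scatter) and a 7.7-fold lower number from compound 1 to compound 4 (0.89 log units; beyond the scatter), so this position separates compounds beyond the scatter even among groups without a hetero atom, which the step from methyl to isopropyl did not show. Against 1-acetylpiperidin-4-yl, cyclopentyl gives an at least 10-fold lower number from compound 3 to compound 4 (1.03 log units; beyond the scatter), so carrying a non-aromatic ring on this nitrogen does not by itself fix the number. Compound 3 stands only at a limit of the assay: the limit of > 10000 nM in this assay, at which 1 of the 4 values shown sits.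

The compounds shown leave open whether cyclohexyl or a piperidin-4-yl amine without the acetyl would fall with compound 4 or with compound 3.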